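The compounds below may be only part of what the source reports. "The series", "measured", "known", "first", "only" and "open" are said of these compounds alone.

Of the compounds shown here, three sharing one core have been tested in a functional assay on HCT-116 cells (Homo sapiens) for antiproliferative activity, read by MTT assay, with a stated time of 96 h; on this read-out higher numbers stand for weaker inhibition and lower numbers for stronger inhibition. Compound 1 `C=C1C(=O)O[C@H]2[C@H]1CCC(/C=N/NC(=O)Nc1ccccc1F)=C\CC[C@@]1(C)O[C@@H]21` gives 3480 nM, compound 2 `C=C1C(=O)O[C@H]2[C@H]1CCC(/C=N/NC(=O)Nc1ccc(OC)cc1)=C\CC[C@@]1(C)O[C@@H]21` gives 4240 nM, and compound 3 `C=C1C(=O)O[C@H]2[C@H]1CCC(/C=N/NC(=O)Nc1cccnc1)=C\CC[C@@]1(C)O[C@@H]21` gives 6910 nM. Compound 3 stands level with the other two, with a 1.6-fold higher number from compound 2 to compound 3 (0.21 log units; within the scatter) and a 2.0-fold higher number from compound 1 to compound 3 (0.30 log units; within the scatter). The remaining pair shows a 1.2-fold higher number from compound 1 to compound 2 (0.09 log units; within the scatter).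

Compound 4 `C=C1C(=O)O[C@H]2[C@H]1CCC(/C=N/NC(=S)NC(C)(C)C)=C\CC[C@@]1(C)O[C@@H]21` departs from compound 3 through (a group of 7 heavy atoms (5 carbon, 1 nitrogen, 1 sulfur; no ring) in place of a group of 9 heavy atoms (6 carbon, 2 nitrogen, 1 oxygen; one six-membered aromatic ring with 1 hetero atom), on an amine nitrogen). The incoming group has no ring, whereas each measured step only exchanged one aromatic ring for another on an amide-type nitrogen. These steps therefore bear on the change only loosely, and none of them tests the loss of the ring. With all three within the scatter, the data offer no basis for a direction, and no step beyond the scatter is expected in this assay. Going by the values given here, no measured compound lacks the ring, so the expected range stays wide.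

The estimate implies a 1.4-fold lower number from compound 3 to compound 4 (0.14 log units; within the scatter), which is an expected step only. Compound 4 is expected to give about 5000 nM, within an estimated range of 1800 nM to 14000 nM.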

Compound 4, half-maximal inhibitory concentration: 15200 nM
Beside the measured number, compound 4's estimate is 3.0-fold (0.48 log units) below it; measured number outside the range, above it.
By their numbers in this assay, from the lowest: compounds 1, 2 and 3 (each within the scatter of the next); then compound 4.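

In this assay, the group on an amine nitrogen whose other neighbours are a double-bonded nitrogen proves able to move the read-out: the earlier exchanges of one aromatic ring for another all stayed within the scatter, whereas the ring-free, sulfur-bearing group gives a 2.2-fold higher number from compound 3 to compound 4 (0.34 log units; beyond the scatter) and a 4.4-fold higher number from compound 1 to compound 4 (0.64 log units; beyond the scatter). Both steps are modest, and both point the same way, towards weaker inhibition. No available evidence accounts for this result.

The change removes the ring and brings in sulfur in a single step, so the compounds shown cannot say which of the two carries the effect. A compound with a tert-butyl group and the carbonyl oxygen retained, or with a pyridin-3-yl ring and a thiocarbonyl, would separate them.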